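A few compounds are considered here, and "the series" means these few. Any claim that something is new, unique, unknown or untested is made for them only; others in the source may bear on it.

Of the compounds shown here, three built on one shared core have been tested in a functional assay on HCT-15 cells (Homo sapiens) for inhibition, read by sulforhodamine B assay, with a stated time of 48 h, tested at 10 uM; on this read-out higher numbers stand for more inhibition at the one concentration tested (going by the name of the read-out) and lower numbers for less inhibition. Compound 1 `c1ccc(-c2cn3ccnc3c(-c3ccc4ncn(C5CCCCC5)c4c3)n2)cc1` gives 51.6% there, compound 2 `COc1ccc(-c2cn3ccnc3c(-c3ccc4ncn(C5CCCCC5)c4c3)n2)cc1` gives 78.8%, and compound 3 `Brc1ccc(-c2cn3ccnc3c(-c3ccc4ncn(C5CCCCC5)c4c3)n2)cc1` gives 35.8%, the lowest of the three. Compound 4 `COc1ccccc1-c1cn2ccnc2c(-c2ccc3ncn(C4CCCCC4)c3c2)n1` differs from compound 3 in one way: 2-methoxyphenyl in place of 4-bromophenyl on an aromatic carbon. Going by the values given here, two measured steps bear on this change. Swapping methoxy for bromo cost a lot, as a number 43 percentage points lower from compound 2 to compound 3 (beyond the scatter) shows, and adding bromo alone also hurt, since a number 15.8 percentage points lower from compound 1 to compound 3 (beyond the scatter), whereas a number 27.2 percentage points higher from compound 1 to compound 2 (beyond the scatter). Removing the bromo and restoring a methoxy, now as a 2-methoxyphenyl, is therefore expected to raise inhibition beyond the scatter. The expected step is a number 26.2 percentage points higher from compound 3 to compound 4 (beyond the scatter). Compound 4 is estimated at 62%, with a range from 38% to 85%.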

Compound 4, a percentage reported as inhibition, at one concentration (the size of the read-out at that concentration, not a potency): 33.6%
The estimate for compound 4 lay 28.4 percentage points above the measured number; the measured number lies below the stated range.
By their numbers in this assay, from the lowest: compounds 4 and 3 (each within the scatter of the next); then compound 1; then compound 2.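

In this assay, the effect of a methoxy group depends on where it sits: 2-methoxyphenyl in place of 4-methoxyphenyl gives a number 45.2 percentage points lower from compound 2 to compound 4 (beyond the scatter), and 2-methoxyphenyl in place of plain phenyl gives a number 18 percentage points lower from compound 1 to compound 4 (beyond the scatter), the opposite direction to the step to the 4-methoxyphenyl compound. The 2-methoxyphenyl and 4-bromophenyl groups cannot be told apart here, with a number 2.2 percentage points lower from compound 3 to compound 4 (within the scatter). Nothing available explains this dependence on placement.

Still open, on these data alone, is how a phenyl ring carrying an amine or a carboxylic acid would behave in this assay.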